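The source may hold more compounds than are shown below. What is called first, only, known or untested is meant among the compounds shown, and "the series" means these compounds.

Among the compounds with values here, in a functional assay on SW982 cells (Homo sapiens) for inhibition, read by MTT assay, with a stated time of 72 h (on this read-out higher numbers stand for weaker inhibition and lower numbers for stronger inhibition), compound 1 `COc1cc(OC)c(OC)cc1/C=C/C(=O)c1cc(Cc2ccccc2)cc(Cc2ccccc2)c1` gives 69900 nM, the only true number so far. Compound 3 `COc1cc(OC)c(-c2cc(=O)c3cc(Cl)ccc3o2)cc1OC` gives > 150000 nM, which is a limit of the assay. Compound 2 `COc1cc(OC)c(OC)cc1/C=C/C(=O)c1ccccc1` stands at the limit of > 150000 nM in this assay, at which 2 of the 3 values shown sit. Its > 150000 nM is likewise a limit and not a number.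

Compound 4 `COc1cc(OC)c(OC)cc1/C=C/C(=O)c1ccc(F)cc1` differs from compound 2 in one place: fluoro in place of hydrogen on an aromatic carbon. In words, this is fluoro in place of hydrogen on an aromatic carbon, turning phenyl into 4-fluorophenyl. Within the data shown here, no measured pair shows what this swap does, so no step beyond the scatter is expected, in either direction. The estimated change is an at least 1.1-fold lower number from compound 2 to compound 4 (0.06 log units; that floor lies within the scatter). For compound 4 the expected value is 130000 nM, with an estimated range from 60000 nM to 280000 nM.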

Compound 4, half-maximal inhibitory concentration: 32500 nM
The estimate for compound 4 lay 4.0-fold (0.60 log units) above the measured number; the whole stated range lies above it.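

Replacing hydrogen with fluoro, which turns phenyl into 4-fluorophenyl, gives an at least 4.6-fold lower number from compound 2 to compound 4 (0.66 log units; beyond the scatter) in this assay. This shows that a single atom at this position of the ring can shift the read-out beyond the scatter. The true size of the step remains unknown because it is only a floor, set by a limit of the assay: the limit of > 150000 nM in this assay, at which 2 of the 4 values shown sit.

Going by these compounds, how chloro, an amine or a carboxylic acid would read on this same carbon remains open, so fluoro cannot yet be called special. Also open, on these data alone, is whether fluoro on another carbon of this ring would give a similar step.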